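The compounds below may be only part of what the source reports. "The series", "measured", "known", "first", "only" and "open" are said of these compounds alone.

Two compounds of the series have numbers in an in vitro assay on HEK293f cells for displacement of a labelled ligand from pituitary adenylate cyclase-activating polypeptide type I receptor (Homo sapiens); on this read-out lower numbers stand for stronger inhibition and higher numbers for weaker inhibition. Compound 1 `COc1cc(/C=N/NC(=O)c2ccc(O)c(Cl)c2)cc(OCc2c(C)c(C)cc(C)c2C)c1OC` gives 167 nM in this assay. Compound 2 `COc1cc(/C=N/NC(=O)c2ccc(O)c(Cl)c2)cc(OC)c1OCc1ccccc1` gives 185 nM in this assay. Compound 2 holds the higher of the two numbers, yet its gap to compound 1 falls within the scatter, so the two are not separated. Compound 3 `COc1cc(/C=N/NC(=O)c2ccc(O)c(Cl)c2)cc(OC)c1OCc1ccc(C(F)(F)F)cc1` has not been measured. It differs from compound 2 in one place: trifluoromethyl in place of hydrogen on an aromatic carbon. Going by the values given here, no measured step of this kind exists. Because compound 1 gives 167 nM and lies within the scatter of compound 2 while differing from it only at the benzyl part, a change at that benzyl is not expected to move the number far. The expected step from compound 2 to compound 3 is therefore a 1.2-fold lower number from compound 2 to compound 3 (0.09 log units; within the scatter), small and not clearly beyond the scatter. For compound 3 the estimate in this assay is 150 nM, with a range from 50 nM to 450 nM.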

Compound 3, inhibition constant: 140 nM
Beside the measured number, compound 3's estimate is 1.1-fold (0.03 log units) above it, within the range that was stated.
By their numbers in this assay, from the lowest: compounds 3, 1 and 2 (each within the scatter of the next).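

In this assay, going by these compounds alone, the change from benzyl to 4-(trifluoromethyl)benzyl gives a 1.3-fold lower number from compound 2 to compound 3 (0.12 log units; within the scatter) and is the first direct step at this place on the ring, para to a large group. It shows that a group of 4 heavy atoms, with no hydrogen-bond donors or acceptors, can replace hydrogen here without separating the number from that of compound 2. No measurement in hand explains this outcome.

Going by these compounds, whether an amine or a carboxylic acid at the same place would also leave the number within the scatter remains open, as does the outcome for a longer chain. With trifluoromethyl as the only group shown here, the result cannot yet be extended to other groups at this position.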